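The compounds below may be only part of what the source reports. "The series", "measured", "known", "first", "only" and "open" are said of these compounds alone.

Measured compounds:
- compound 1, `COc1ccccc1N1CCN(CCCNc2ncc(C#N)cc2C(=O)N(C)C)CC1`: 0.794 nM
- compound 2, `COc1ccccc1N1CCN(CCCNc2ccc(C(=O)N(C)C)cn2)CC1`: 25.1 nM
- compound 3, `CN(C)C(=O)c1cccnc1NCCCN1CCN(c2ccccc2)CC1`: 6.31 nM

All three were tested in a functional assay for antagonist activity at Alpha-1A adrenergic receptor (Oryctolagus cuniculus); a lower number here means tighter binding, a higher number weaker binding. Among the three numbers, compound 3 stands second highest with 6.31 nM. Its nearest neighbour is compound 2, which gives 25.1 nM, a gap beyond the usual scatter; furthest from it is compound 1, which gives 0.794 nM, also beyond the scatter. For the measured compounds named here, compounds 1 and 2 each differ from compound 3 in more than one place, so no single-change step between measured compounds is available, and only the bare values can be compared.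

The next compound, compound 4, `COc1cc(C)ccc1N1CCN(CCCNc2ncccc2C(=O)N(C)C)CC1`, has not yet been measured. It differs from compound 3 in one place: 2-methoxy-4-methylphenyl in place of phenyl on an amine nitrogen in a ring. The shared core and the chain that links it to the ring amine are untouched.

Going by the values given here, with no measured step of the same kind to lean on, the expectation is a modest move toward a lower number, roughly the size of a 2.5-fold lower number from compound 3 to compound 4 (0.40 log units; beyond the scatter), and well within the span covered by compounds 1 and 2. Compound 4 is therefore estimated at 2.5 nM, with a likely range from 0.6 nM to 10 nM.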

Compound 4, dissociation constant: 0.794 nM
Estimate against measurement, compound 4: 3.1-fold (0.50 log units) above, and the stated range covers the measured number.
By their numbers in this assay, from the lowest: compounds 1 and 4 (each within the scatter of the next); then compound 3; then compound 2.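

For the compounds shown here, replacing phenyl with 2-methoxy-4-methylphenyl on an amine nitrogen in a ring gives a 7.9-fold lower number from compound 3 to compound 4 (0.90 log units; beyond the scatter) in this assay, and this is the first single-change step available in this small set. It shows that the aromatic ring on this nitrogen matters for the measured number, and that this larger group, with more heavy atoms and one hydrogen-bond acceptor where phenyl has none, goes with tighter binding while the shared core and its chain stay the same. Nothing shown here explains why the number falls.

The new group brings a methoxy and a methyl in a single change, so this one step cannot divide the shift between them, and a ring carrying only the methoxy or only the methyl would be needed to tell them apart. From the compounds shown here alone, how this position responds to other groups, such as a chlorophenyl, an ethoxyphenyl or a pyridyl ring, also remains open, as does whether the same change would give a step of similar size on a different core.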